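Swapping oxygen for sulfur in a cell toxicity test

This account rests on a few compounds, and the source may have more. Where it says the series, first, only, none or still open, it means among the compounds named here.

Measured in a toxicity assay on MDCK cells (Canis lupus familiaris) for cytotoxicity, read by crystal violet staining, with a stated time of 48 h; on this read-out lower numbers stand for higher toxicity in this test and higher numbers for lower toxicity in this test:
- Compound 1 `Cc1ccc2[nH]c(=O)c(CN(Cc3ccc(O)cc3)Cc3ccc(C(C)(C)C)cc3)cc2c1`: 4900 nM
- Compound 2 `Cc1ccc2[nH]c(=O)c(CN(Cc3ccc(C(N)=O)cc3)Cc3ccc(C(C)(C)C)cc3)cc2c1`: > 5000 nM, a limit and not a number
- Compound 3 `Cc1ccc2[nH]c(=O)c(CN(Cc3ccc(OC(F)(F)F)cc3)Cc3ccc(C(C)(C)C)cc3)cc2c1`: > 5000 nM, a limit and not a number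

Compound 3 stands at > 5000 nM, so only a limit is known for it. Across the set, the numbers show (the limit of > 5000 nM in this assay, at which 2 of the 3 values shown sit).

Compound 4 `Cc1ccc2[nH]c(=O)c(CN(Cc3ccc(SC(F)(F)F)cc3)Cc3ccc(C(C)(C)C)cc3)cc2c1` differs from compound 3 in one group, with (trifluoromethyl)sulfanyl in place of trifluoromethoxy on an aromatic carbon.

Among the measured compounds shown here, no measured step makes this exact swap, but all three change the same group. One is an at least 1.0-fold higher number from compound 1 to compound 3 (0.00 log units; that floor lies within the scatter). Another is an at least 1.0-fold higher number from compound 1 to compound 2 (0.00 log units; that floor lies within the scatter). The third is a step that the two limits leave unreadable from compound 2 to compound 3. These steps therefore give only a loose guide to the new change.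

Compound 1, at 4900 nM, carries a different group, so no step beyond the scatter is expected in this assay, in either direction. The expected size is a number no higher from compound 3 to compound 4 (the limit leaves the size open). A report of only a limit is also likely for compound 4.

The estimate for compound 4 is 5000 nM, with an expected range from 2800 nM to 9000 nM.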

Compound 4, half-maximal cytotoxic concentration: > 5000 nM
Compound 4 gave a limit, no number (the forecaster's own chance of this, stated with the estimate: 70%); the middle value lies on the limit itself.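

In this assay compound 4 gives > 5000 nM as a limit and not a number. Among the compounds shown here, the only step that can be read is an at least 1.0-fold higher number from compound 1 to compound 4 (0.00 log units; that floor lies within the scatter) and its floor lies within the scatter, while the steps among compounds 2, 3 and 4 cannot be read. Trading trifluoromethoxy for (trifluoromethyl)sulfanyl on this aromatic carbon, para to a large group, therefore gives no number to set against compound 3, and the limit now holds most of the set: the limit of > 5000 nM in this assay, at which 3 of the 4 values shown sit.

The compounds shown leave open how far compounds 2, 3 and 4 differ from one another in this assay and whether any of them would give a number under other test conditions. They also leave open whether a carboxylic acid, an amine or a longer chain at this place would give a number, as compound 1 does with 4900 nM and its hydroxy group.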